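Swapping the halogen on the anilino ring

A few compounds are considered here, and "the series" means these few. Any claim that something is new, unique, unknown or untested is made for them only; others in the source may bear on it.

Compounds measured so far:
Compound 1, `COc1cc2ncnc(Nc3ccc(Cl)c(C(F)(F)F)c3)c2cc1OCCCCC(=O)Nc1ccc(S(N)(=O)=O)cc1`: 3910 nM in a functional assay on A-431 cells (Homo sapiens) for antiproliferative activity, read by MTT assay, with a stated time of 72 h; on this read-out higher numbers stand for weaker inhibition and lower numbers for stronger inhibition
Compound 2, `COc1cc2ncnc(Nc3cccc(Br)c3)c2cc1OCCCCC(=O)Nc1ccc(S(N)(=O)=O)cc1`: 9750 nM in this assay
Compound 3, `COc1cc2ncnc(Nc3cccc(F)c3)c2cc1OCCCCC(=O)Nc1ccc(S(N)(=O)=O)cc1`: 29900 nM in this assay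

Compound 3 stands at the highest number of the three, so it is the weakest inhibitor of cell growth here. The next compound, compound 4, is `COc1cc2ncnc(Nc3ccc(Cl)cc3)c2cc1OCCCCC(=O)Nc1ccc(S(N)(=O)=O)cc1`; the change from compound 3 is 4-chlorophenyl in place of 3-fluorophenyl on a nitrogen on an aromatic ring. Going by the values given here, two measured steps bear on this: a 3.1-fold higher number from compound 2 to compound 3 (0.49 log units; beyond the scatter), where bromo replaced by fluoro weakened inhibition, and a 7.6-fold higher number from compound 1 to compound 3 (0.88 log units; beyond the scatter). Both show that a fluorine on this ring gives the weakest result, while a heavier halogen lowers the number. A chlorine is expected to behave more like bromine than fluorine, so a modest lowering is expected, a 2.5-fold lower number from compound 3 to compound 4 (0.40 log units; beyond the scatter). Compound 4 is therefore estimated at 12000 nM, with a range from 4000 nM to 35000 nM.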

Compound 4, half-maximal inhibitory concentration: 7120 nM
Compound 4: middle estimate off by 1.7-fold (0.23 log units), on the high side, within the range that was stated.
By their numbers in this assay, from the lowest: compounds 1, 4 and 2 (each within the scatter of the next, the first and the last beyond it); then compound 3.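

In this assay, changing 3-fluorophenyl to 4-chlorophenyl gives a 4.2-fold lower number from compound 3 to compound 4 (0.62 log units; beyond the scatter) and so moves the compound clear of the fluorine result, although both the halogen and its place change. By contrast, 4-chlorophenyl cannot be told apart from 3-bromophenyl, with a 1.4-fold lower number from compound 2 to compound 4 (0.14 log units; within the scatter) within the scatter, and a 1.8-fold higher number from compound 1 to compound 4 (0.26 log units; within the scatter) shows that removing trifluoromethyl has no readable effect. No supporting measurement bears on the reason for these results.

Going by these compounds, whether the halogen or its place drives the change stays open, and 3-chlorophenyl and 4-fluorophenyl would separate the two. On these data alone, the effect of a methoxy group or an amine on this ring is also open.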